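Swapping the aryl group on a cyanoguanidine in a vasorelaxant series

The source may hold more compounds than are shown below. What is called first, only, known or untested is meant among the compounds shown, and "the series" means these compounds.

Measured compounds:
compound 1 `CC1(C)Oc2ccc(C#N)cc2[C@@H](/N=C(\NC#N)Nc2ccc(N)cc2)[C@@H]1O` — 3500 nM
compound 2 `C/N=C(\NC#N)N[C@@H]1c2cc(C#N)ccc2OC(C)(C)[C@H]1O` — 200 nM
compound 3 `COC(=O)c1cc2ccccc2n1[C@@H]1c2cc(C#N)ccc2OC(C)(C)[C@H]1O` — 33100 nM

Three compounds sharing one core were tested in a functional assay (aorta) with Rattus norvegicus as the target; a higher number here means a weaker inhibitor, a lower number a stronger inhibitor. Compound 1 stands second highest of the three; compound 3 lies far above it and compound 2 far below it, both gaps beyond the scatter. The piece now turns to compound 4 `Cc1cccc(N/C(=N/[C@@H]2c3cc(C#N)ccc3OC(C)(C)[C@H]2O)NC#N)c1`, which differs from compound 1 in one place: 3-methylphenyl in place of 4-aminophenyl on an amine nitrogen.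

Among the compounds with values here, no measured pair shows this exact change, so the expectation rests on compound 1 alone. The step of a 1.8-fold lower number from compound 1 to compound 4 (0.24 log units; within the scatter) is expected to be small, toward a lower number, and close to the scatter. Compound 4 is therefore estimated at 2000 nM, with a range from 500 nM to 8000 nM.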

Compound 4, half-maximal inhibitory concentration: 1000 nM
Compound 4: the middle estimate sits 2.0-fold (0.30 log units) above what was measured; the range from low to high includes it.
By their numbers in this assay, from the lowest: compound 2; then compound 4; then compound 1; then compound 3.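

In this assay, replacing 4-aminophenyl with 3-methylphenyl on the amine nitrogen gives a 3.5-fold lower number from compound 1 to compound 4 (0.54 log units; beyond the scatter) and takes the number beyond the scatter. Within the data shown here, this is the first single-place comparison in the set, and it shows that this position responds to the choice of aryl group. The change also removes the hydrogen-bond donor and acceptor counted on the leaving group without a loss in this assay, but no available measurement accounts for the step. On these data alone, it remains open whether the step follows from losing the amino group, gaining the methyl or the changed placement, which a plain phenyl or a 3-aminophenyl group on this nitrogen would help separate.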